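The source may hold more compounds than are shown below. What is called first, only, known or untested is meant among the compounds shown, and "the series" means these compounds.

In a functional assay on P388D1 cells (Homo sapiens) for antiproliferative activity, read by sulforhodamine B assay, with a stated time of 48 h (on this read-out higher numbers stand for weaker inhibition and lower numbers for stronger inhibition), three compounds that share most of their structure have been measured: compound 1 (`O=C1NCCN1c1ccc(S(=O)(=O)Nc2ccc3[nH]ccc3c2)cc1`) gives 520 nM, compound 2 (`Cc1cccc(NS(=O)(=O)c2ccc(N3CCNC3=O)cc2)c1`) gives 250 nM, and compound 3 (`Cc1cc(C)cc(NS(=O)(=O)c2ccc(N3CCNC3=O)cc2)c1`) gives 210 nM. Compound 3 therefore has the lowest of the three numbers, but it cannot be separated from compound 2 within the scatter, and only compound 1 stands clearly apart from it.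

The unmeasured compound 4 (`COc1cccc(NS(=O)(=O)c2ccc(N3CCNC3=O)cc2)c1`) has 3-methoxyphenyl in place of 3,5-dimethylphenyl on a sulfonamide nitrogen. For the measured compounds named here, only one measured step comes close to this change. It is methyl in place of hydrogen on an aromatic carbon, a 1.2-fold lower number from compound 2 to compound 3 (0.08 log units; within the scatter). That small step suggests that losing one methyl should matter little. Going by the values given here, no measured compound carries a methoxy group, so that part of the change remains untested, and the range has to stay wide.

No step beyond the scatter is expected in this assay. The expected step is a 1.2-fold higher number from compound 3 to compound 4 (0.08 log units; within the scatter). For compound 4, the estimated value is 250 nM, with an expected range of 120 nM to 520 nM.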

Compound 4, half-maximal inhibitory concentration: 250 nM
For compound 4 middle estimate and measured number coincide at the digits printed; the range from low to high includes it.
By their numbers in this assay, from the lowest: compounds 3, 2 and 4 (each within the scatter of the next); then compound 1.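

In this assay, 3-methoxyphenyl in place of 3,5-dimethylphenyl on a sulfonamide nitrogen gives a 1.2-fold higher number from compound 3 to compound 4 (0.08 log units; within the scatter), the first sign that a group containing oxygen can stand here. Methoxy in place of methyl on an aromatic carbon gives no change at the digits printed from compound 2 to compound 4 (within the scatter), so among these compounds, a group with a hydrogen-bond acceptor performs no differently from one without. Nothing available explains this result.

The compounds shown leave open whether a larger change on this ring, such as an amine, a carboxylic acid or a longer chain like butoxy, would move the number beyond the scatter. Going by these compounds, they also vary only the group on the sulfonamide nitrogen, so the effect of changing the shared core remains unknown.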